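Amino Removal from the Core: Expected Maximal Response

The compounds below may be only part of what the source reports. "The series", "measured", "known", "first", "only" and "open" are said of these compounds alone.

Measured so far:
compound 1 `CC1(C)CN(C2=CCCC2=O)c2cc(N)ccc2S1` — 96%
compound 2 `CC1CN(C2=CCCC2=O)c2cc(C(F)(F)F)ccc2S1` — 94%
compound 3 `CC1(C)CSc2ccc(C(F)(F)F)cc2N1C1=CCCC1=O` — 89%

In a functional assay on aorta (Rattus norvegicus, strain Wistar) (on this read-out lower numbers stand for smaller maximal responses and higher numbers for larger maximal responses), compound 1 gives 96%, compound 2 gives 94% and compound 3 gives 89%. Compound 1 holds the top number of the three, yet its gaps to compound 2 and to compound 3 both lie within the scatter, so the three compounds are not separable on this read-out. Among the compounds with values here, no pair of measured compounds differs in a single place, so no measured step is available.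

Compound 4 `CC1(C)CN(C2=CCCC2=O)c2ccccc2S1` has not been measured. Relative to compound 1 the change is hydrogen in place of amino on an aromatic carbon. With all three measured compounds giving near-full maximal responses, the step is expected to be none beyond the scatter: a number 4 percentage points lower from compound 1 to compound 4 (within the scatter) is the estimated step. Compound 4 is expected to give 92%, within 80% to 100%.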

Compound 4, largest response reached (Emax), in percent of the reference or control that the assay uses: 90%
Beside the measured number, compound 4's estimate is 2 percentage points above it, and the stated range covers the measured number.
By their numbers in this assay, from the lowest: compounds 3, 4, 2 and 1 (each within the scatter of the next).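

Hydrogen in place of amino on this aromatic carbon gives the first single-place step in the series, a number 6 percentage points lower from compound 1 to compound 4 (within the scatter) in this assay. In this pair, a response of this size therefore does not depend on the amino group, and losing its hydrogen-bond donor and acceptor produces no separable change. No available evidence bears on the reason for this result.

Still open, going by these compounds, is how a carboxylic acid or a methoxy group on this aromatic carbon would read out. Also open, on these data alone, is whether a dimethylamino group would behave like amino or hydrogen.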